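The compounds below may be only part of what the source reports. "The series", "measured", "known", "first", "only" and "open" are said of these compounds alone.

Compound 1 `COc1ccc(NS(C)(=O)=O)c2c1C(c1c[nH]cn1)CCC2`: < 10000 nM
Compound 2 `Cc1ccc(NS(C)(=O)=O)c2c1C(c1c[nH]cn1)CCC2`: < 10000 nM

In an assay on isolated protein (Cricetulus griseus) for binding affinity to Alpha-1B adrenergic receptor (Mesocricetus auratus), read by radioligand binding (on this read-out higher numbers stand for weaker inhibition and lower numbers for stronger inhibition), compound 1 gives only a limit, < 10000 nM. In this assay compound 2 likewise gives only a limit, < 10000 nM. Going by the values given here, the single measured step, a step that the two limits leave unreadable from compound 1 to compound 2, therefore cannot be sized, and the limit of < 10000 nM in this assay, at which 2 of the 2 values shown sit, is the whole of what the two values show. Compound 3 `CS(=O)(=O)Nc1ccc(Cl)c2c1CCCC2c1c[nH]cn1` differs from compound 2 by chloro in place of methyl on an aromatic carbon. Among the compounds with values here, no measured step bears on this exchange, and the two limits leave the standing of compound 2 itself open, so no direction beyond the usual scatter can be expected in this assay from this change. The estimate for compound 3 is 1500 nM, with a range of 100 nM to 10000 nM. The step this implies, a step that the limit leaves unreadable from compound 2 to compound 3, is an expectation only, and there is a fair chance that compound 3 again returns only a limit.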

Compound 3, inhibition constant: < 10000 nM
Compound 3: a limit, no number (the forecaster's own chance of this, stated with the estimate: 50%); the middle value lies beyond the limit too.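

In this assay compound 3 gives only a limit, not a number, so the steps to it from compound 1 and compound 2 cannot be read. On these data alone, the actual affinity of all three compounds remains open, as does whether methoxy, methyl or chloro on that aromatic carbon makes any difference.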